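The source may report more compounds than this note shows. Statements on the series, on what has been measured and on what is new or still open speak of the compounds shown alone.

Compound 2 (`Cn1c(=O)c(S(=O)(=O)c2ccc(F)cc2F)cc2cnc(Nc3ccc4occc4c3)nc21`) carries the highest number of the three compounds measured in a functional assay on K562 cells (Homo sapiens) for inhibition, read by trypan blue exclusion, with a stated time of 72 h (on this read-out higher numbers stand for weaker inhibition and lower numbers for stronger inhibition), where compound 2 gives 15000 nM. Going by the values given here, its closest relative, compound 1 (`Cn1c(=O)c(S(=O)(=O)c2ccc(F)cc2)cc2cnc(Nc3ccc4occc4c3)nc21`), gives 5000 nM in this assay, and the single step between them, a 3.0-fold higher number from compound 1 to compound 2 (0.48 log units; beyond the scatter), concerns only a fluoro in place of hydrogen on an aromatic carbon. Compound 3 (`Cn1c(=O)c(S(=O)(=O)c2ccc(Cl)cc2)cc2cnc(Nc3cccc4[nH]ccc34)nc21`) gives 5000 nM in this assay, the same number as compound 1.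

Compound 4 (`Cc1cc2cc(Nc3ncc4cc(S(=O)(=O)c5ccc(F)cc5F)c(=O)n(C)c4n3)ccc2[nH]1`) differs from compound 2 in a different place: 2-methyl-1H-indol-5-yl in place of 1-benzofuran-5-yl on a nitrogen on an aromatic ring. Among the compounds with values here, no measured step touches this part of the molecule, so the step of a 3.0-fold higher number from compound 1 to compound 2 (0.48 log units; beyond the scatter) does not directly bear on it, and compound 3 differs from compound 1 in two places, so its value alone cannot be read as a step. Within the data shown here, with no directly relevant step, the expectation for compound 4 in this assay is a modest move toward lower numbers, estimated as a 1.5-fold lower number from compound 2 to compound 4 (0.18 log units; within the scatter). Compound 4 is expected to give 10000 nM in this assay, with a range from 4000 nM to 30000 nM.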

Compound 4, half-maximal inhibitory concentration: 750 nM
Compound 4: the middle estimate sits 13-fold (1.12 log units) above what was measured; the measured number lies below the stated range.
By their numbers in this assay, from the lowest: compound 4; then compounds 1 and 3 (each within the scatter of the next); then compound 2.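

The step of a 20-fold lower number from compound 2 to compound 4 (1.30 log units; beyond the scatter) shows that in this assay the group on the nitrogen on an aromatic ring can shift the read-out much further than the fluoro change did (a 3.0-fold higher number from compound 1 to compound 2 (0.48 log units; beyond the scatter)). Compound 4 keeps the added fluoro of compound 2, so this large step arises on the background that gave the highest number among the first three compounds. Nothing available accounts for the size of this step.

The step brings in the ring nitrogen with its hydrogen and the methyl together, so their shares remain unresolved, and a plain 1H-indol-5-yl group would be needed to separate them. As far as these compounds go, whether the same exchange carries over to the core of compound 1, with its single fluoro, also remains open.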